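The source may report more compounds than this note shows. Statements on the series, on what has been measured and on what is new or still open speak of the compounds shown alone.

In a functional assay on SH-SY5Y cells (Homo sapiens) for cytotoxicity, read by MTT assay, with a stated time of 72 h (a lower number here means a stronger inhibitor, a higher number a weaker inhibitor), compound 3 (`CC1(C)O[C@@H](CO)[C@H](Cn2cc(Cn3c4c(c5ccccc53)C(=O)c3c[n+]([O-])c5ccccc5c3C4=O)nn2)O1`) gives > 1000 nM as a limit and not a number. Compound 2 (`O=C1c2c[n+]([O-])c3ccccc3c2C(=O)c2c1c1ccccc1n2Cc1cn(C[C@H](O)CO)nn1`) likewise gives > 1000 nM as a limit. Within the data shown here, compound 1 (`O=C1c2c[n+]([O-])c3ccccc3c2C(=O)c2c1c1ccccc1n2Cc1cn([C@H]2O[C@H](CO)[C@@H](O)[C@H]2O)nn1`) gives 1340 nM as the only exact number. The series thus rests largely on the limit of > 1000 nM in this assay, at which 2 of the 3 values shown sit, and compound 3 has no exact place within it.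

The change to compound 4 (`O=C1c2c[n+]([O-])c3ccccc3c2C(=O)c2c1c1ccccc1n2Cc1cn([C@@H]2O[C@H](CO)[C@@H](O)[C@H](O)[C@H]2O)nn1`) is a single replacement (3,4,5-trihydroxy-6-(hydroxymethyl)oxan-2-yl in place of (5-(hydroxymethyl)-2,2-dimethyl-1,3-dioxolan-4-yl)methyl on an aromatic nitrogen) on the shared core. The measured steps that bear on it are (a step that the limit leaves unreadable from compound 1 to compound 3) and (a step that the limit leaves unreadable from compound 1 to compound 2) but neither has a readable size, so no measured direction carries over. The entering 3,4,5-trihydroxy-6-(hydroxymethyl)oxan-2-yl stands closest to the 3,4-dihydroxy-5-(hydroxymethyl)oxolan-2-yl of compound 1, and its 1340 nM therefore serves as the anchor for the expectation.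

The expected step (a step that the limit leaves unreadable from compound 3 to compound 4) is estimated to stay within the scatter, with no firm direction in this assay at this stage. A report of a limit alone would also fit the series. For compound 4 the expected value is 1500 nM with an estimated range from 600 nM to 5000 nM in this assay as the working figure.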

Compound 4, half-maximal inhibitory concentration: 880 nM
Compound 4: the middle estimate sits 1.7-fold (0.23 log units) above what was measured, within the range that was stated.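

In this assay the 3,4,5-trihydroxy-6-(hydroxymethyl)oxan-2-yl group on the aromatic nitrogen gives the series its first exact comparison: a 1.5-fold lower number from compound 1 to compound 4 (0.18 log units; within the scatter). Among these compounds, exchanging the five-membered ring of compound 1 for this six-membered ring therefore leaves the number within the scatter, and the same holds for the floors of the other two comparisons, an at least 1.1-fold lower number from compound 3 to compound 4 (0.05 log units; that floor lies within the scatter) and an at least 1.1-fold lower number from compound 2 to compound 4 (0.05 log units; that floor lies within the scatter), while the earlier steps among compound 1, compound 2 and compound 3 cannot be read. As far as these compounds go, the true size of these two floor steps stays unknown because compound 2 and compound 3 each carry a limit and not a number: the limit of > 1000 nM in this assay, at which 2 of the 4 values shown sit.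

From the compounds shown here alone, all four groups at this position carry hydroxyl groups, so it remains open how a group of another kind on the same aromatic nitrogen, such as a primary amine, a carboxylic acid or a longer alkyl chain, would read in this assay. Going by these compounds, it also remains open whether any replacement at this position can move the number beyond the scatter, and what a change on the shared core itself would do.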